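Sulfonyl and aroyl variants on a shared core

The source may hold more compounds than are shown below. What is called first, only, known or untested is meant among the compounds shown, and "the series" means these compounds.

Measured so far:
Compound 1 `CN(C(=O)c1ccccc1)c1ccc2[nH]c(-c3n[nH]c4ccccc34)cc2n1`: in a functional assay on KB cells (Homo sapiens) for antiproliferative activity, read by MTT assay, with a stated time of 72 h (a lower number here means a stronger inhibitor, a higher number a weaker inhibitor), compound 1 gives 8580 nM.
Compound 2 `CN(C(=O)c1ccc(F)cc1)c1ccc2[nH]c(-c3n[nH]c4ccccc34)cc2n1`: in this assay compound 2 gives 7220 nM.
Compound 3 `Cc1ccc(S(=O)(=O)N(C)c2ccc3[nH]c(-c4n[nH]c5ccccc45)cc3n2)cc1`: in this assay compound 3 gives 9500 nM.

Compound 3 holds the highest of the three numbers, but its gaps to the others are small: a 1.1-fold higher number from compound 1 to compound 3 (0.04 log units; within the scatter) and a 1.3-fold higher number from compound 2 to compound 3 (0.12 log units; within the scatter). The remaining measured step, a 1.2-fold lower number from compound 1 to compound 2 (0.07 log units; within the scatter), also stays within the scatter. Across the three measured compounds nothing moves beyond the scatter.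

Compound 4 `COc1ccc(S(=O)(=O)N(C)c2ccc3[nH]c(-c4n[nH]c5ccccc45)cc3n2)cc1` differs from compound 3 by methoxy in place of methyl on an aromatic carbon. Going by the values given here, no measured step alters this part of the sulfonyl-bearing ring; the nearest comparison is the fluoro for hydrogen exchange on the aroyl ring, a 1.2-fold lower number from compound 1 to compound 2 (0.07 log units; within the scatter), which stayed within the scatter. On that basis no step beyond the scatter is expected, and the estimated step is a 1.1-fold lower number from compound 3 to compound 4 (0.02 log units; within the scatter). Compound 4 is therefore expected to give about 9000 nM in this assay, with a range from 4500 nM to 18000 nM.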

Compound 4, half-maximal inhibitory concentration: 22100 nM
The estimate for compound 4 lay 2.5-fold (0.39 log units) below the measured number; measured number above the stated range.
By their numbers in this assay, from the lowest: compounds 2, 1 and 3 (each within the scatter of the next); then compound 4.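

In this assay, the change from 4-methylphenyl to 4-methoxyphenyl gives a 2.3-fold higher number from compound 3 to compound 4 (0.37 log units; beyond the scatter), a modest step but the only one among these compounds that lies beyond the scatter. The position para to a large group on the sulfonyl-bearing ring therefore responds to a single substituent exchange, and the direction is toward a weaker inhibitor, whereas the fluoro exchange on the aroyl ring and the exchanges of the aroyl group for the sulfonyl group stayed within the scatter. Nothing on hand accounts for this step.

Open, as far as these compounds go, is whether the rise follows from the added oxygen or from the larger group, which a hydroxyl, an ethyl or a chlorine at the same position would help to separate. Also open, from the compounds shown here alone, is whether methoxy in place of hydrogen on the aroyl ring of compound 1 would move the number in the same direction.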